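Bromo to methyl on the fused ring of compound 2

The source may hold more compounds than are shown below. What is called first, only, known or untested is meant among the compounds shown, and "the series" means these compounds.

Compound 2 `O=c1cc(-c2ccccc2)oc2cc(N3COc4c(Br)cccc4C3)ccc12` sits in the same series as compound 1 `Cc1cc(C)c2c(c1)CN(c1ccc3c(=O)cc(-c4ccccc4)oc3c1)CO2`. In a functional assay on MCF7 cells (Homo sapiens) for inhibition, read by MTT assay, with a stated time of 48 h (on this read-out lower numbers stand for stronger inhibition and higher numbers for weaker inhibition), compound 2 gives "not active" (no number reported), so no number fixes where it stands; compound 1 gives 61900 nM in this assay. Compound 3 `Cc1cccc2c1OCN(c1ccc3c(=O)cc(-c4ccccc4)oc3c1)C2` differs from compound 2 by methyl in place of bromo on an aromatic carbon. For the measured compounds named here, no step between measured compounds covers this change, so its size cannot be read from the series; given compound 1 with 61900 nM, the expectation for compound 3 is weak inhibition, either a high concentration or again no number. Compound 3 is estimated at 80000 nM (range 30000 nM to 200000 nM) in this assay.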

Compound 3, half-maximal inhibitory concentration: 14900 nM
For compound 3 the middle estimate is 5.4-fold (0.73 log units) above the measured one, and the stated range ends above it.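

In this assay compound 3 gives a number where compound 2 gives none, so methyl on this aromatic carbon keeps a reportable value where bromo does not, although the size of that change cannot be read. The step of a 4.2-fold lower number from compound 1 to compound 3 (0.62 log units; beyond the scatter) shows that the other methyl of compound 1 is not required for activity, and that its replacement by hydrogen goes with stronger inhibition. No measurement shown bears on the reason for either result.

Open, as far as these compounds go, is whether chloro, methoxy or an amine on this aromatic carbon would give a number, and how any of them would compare with methyl.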